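Substituent changes on the aromatic ring of the shared core

The source may hold more compounds than are shown below. What is called first, only, known or untested is meant among the compounds shown, and "the series" means these compounds.

Measured in a functional assay on MGC-803 cells (Homo sapiens) for antiproliferative activity, read by MTT assay, with a stated time of 72 h; a lower number here means a stronger inhibitor, a higher number a weaker inhibitor:
compound 1, `O=C1OCC[C@@H]1NC(=S)SCCOc1ccccc1`: 53800 nM
compound 2, `O=C1OCC[C@@H]1NC(=S)SCCOc1ccccc1Cc1ccccc1`: 32300 nM
compound 3, `O=C1OCC[C@@H]1NC(=S)SCCOc1ccccc1[N+](=O)[O-]`: 47000 nM

Compound 3 gives the second highest of the three numbers, but its gaps to compound 1 and to compound 2 both lie within the scatter, so no order among the three is established. The steps recorded so far are a 1.7-fold lower number from compound 1 to compound 2 (0.22 log units; within the scatter), a 1.1-fold lower number from compound 1 to compound 3 (0.06 log units; within the scatter) and a 1.5-fold higher number from compound 2 to compound 3 (0.16 log units; within the scatter); none reaches beyond the scatter. Compound 4, `CCOc1ccccc1OCCSC(=S)N[C@H]1CCOC1=O`, differs from compound 3 by ethoxy in place of nitro on an aromatic carbon. Among the compounds with values here, all three changes made so far at an aromatic carbon of this ring left the number within the scatter, and the swap from compound 2 to compound 3 is the closest precedent. No step beyond the scatter is therefore expected in this assay for compound 4, that is a 1.0-fold lower number from compound 3 to compound 4 (0.02 log units; within the scatter). The estimate for compound 4 is 45000 nM, with a range of 20000 nM to 100000 nM.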

Compound 4, half-maximal inhibitory concentration: > 64000 nM
Compound 4 was reported as a limit; the forecaster's own chance of this, stated with the estimate: 10%; middle value at least 1.4-fold (0.15 log units) away from the limit.
By their numbers in this assay, from the lowest: compounds 2, 3 and 1 (each within the scatter of the next). At a limit, above all of these: compound 4.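

Compound 4 is reported in this assay only as a limit, > 64000 nM. Ethoxy on this aromatic carbon, ortho to a large group, is the only change here without a measured endpoint, and an at least 1.3-fold higher number from compound 3 to compound 4 (0.13 log units; that floor lies within the scatter), an at least 1.9-fold higher number from compound 2 to compound 4 (0.29 log units; that floor lies within the scatter) and an at least 1.1-fold higher number from compound 1 to compound 4 (0.07 log units; that floor lies within the scatter) all rest on floors within the scatter, so no separation from nitro, benzyl or hydrogen is established. The reading of this change is bounded by: the limit of > 64000 nM in this assay, at which 1 of the 4 values shown sits.

As far as these compounds go, the true value of compound 4 stays open. Also open, from the compounds shown here alone, is whether an amine or a carboxylic acid on this carbon would move the number beyond the scatter.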